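A few compounds are considered here, and "the series" means these few. Any claim that something is new, unique, unknown or untested is made for them only; others in the source may bear on it.

Of the compounds shown here, three have so far been tested in a functional assay on EL4 cells (Mus musculus) for inhibition, tested at 100 uM; a higher number here means more inhibition at the concentration tested (going by the name of the read-out), a lower number less inhibition. Compound 1 `CN(C)c1nccc2c1ncn2C1O[C@H](CO)[C@@H](O)[C@H]1O` gives 10% in this assay. Compound 3 `CNc1nccc2c1ncn2C1O[C@H](CO)[C@@H](O)[C@H]1O` gives 11% in this assay. The change from compound 1 to compound 3 is hydrogen in place of methyl on a nitrogen on an aromatic ring, and the step it made, a number 1 percentage points higher from compound 1 to compound 3 (within the scatter), is small. Compound 2 `CNc1[nH]ccc2ncnc1-2` is built on a different core; the difference between the two cores is not broken down here. In this assay compound 2 gives only a limit, < 5%, not a number. This is the limit of < 5% in this assay, at which 1 of the 3 values shown sits.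

Compound 4 `Nc1[nH]ccc2ncnc1-2` has not been measured yet. It differs from compound 2 by hydrogen in place of methyl on a nitrogen on an aromatic ring, the same kind of change as that from compound 1 to compound 3, though here the ring nitrogen's other neighbour is aromatic carbon alone, where before it was aromatic carbon together with a saturated chain carbon. Because a number 1 percentage points higher from compound 1 to compound 3 (within the scatter) stayed within the scatter, the same kind of change is expected to move little here. The step to compound 4 is estimated as a number no lower from compound 2 to compound 4 (the limit leaves the size open). Compound 4 is therefore expected to give 5% in this assay, within a range from 0% to 15%.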

Compound 4, a percentage reported as inhibition, at one concentration (the size of the read-out at that concentration, not a potency): < 5%
Compound 4 was reported as a limit; the forecaster's own chance of this, stated with the estimate: 60%; the middle value sits exactly at the limit.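

Compound 2 and compound 4 are both reported only as limits in this assay, not as numbers, so no step between them can be read: the limit of < 5% in this assay, at which 2 of the 4 values shown sit.

The compounds shown leave open whether going from methylamino to amino on the core of compound 2 changes inhibition at all, as it could not be seen here.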